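The source may hold more compounds than are shown below. What is called first, only, known or untested is meant among the compounds shown, and "the series" means these compounds.

Four compounds built on a shared core, each carrying a chain that ends in a substituted aromatic ring, were examined in an ADME assay on HEL cells (Homo sapiens) for cytotoxicity; on this read-out lower numbers stand for higher toxicity in this test and higher numbers for lower toxicity in this test. Compound 1 `Cc1cn(CCCCCOc2ccc(Br)cc2)c(=O)[nH]c1=O` reaches only a limit in this assay, with compound 1 reported as > 100000 nM. That figure is a boundary of the test and not a number: the limit of > 100000 nM in this assay, at which 1 of the 3 values shown sits. Compound 3 `O=c1ccn(CCCCOc2ccc(Br)cc2)c(=O)[nH]1` has no result in this assay, its entry reading "not determined" (no result reported). Among the measured compounds shown here, compound 2 `CC(C)(C)c1ccc(OCCCCCn2ccc(=O)[nH]c2=O)cc1` gives 40000 nM in this assay, and this is the only single number in the set. For the measured compounds named here, compound 2 therefore stands alone as a measured value, and no step between measured compounds can be drawn from these data.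

Compound 4 `Nc1ccc(OCCCCCn2ccc(=O)[nH]c2=O)cc1` differs from compound 2 in one place: amino in place of tert-butyl on an aromatic carbon.

Going by the values given here, with no measured step to lean on, the account expects a change in this assay of no more than the usual scatter, in either direction. For compound 4 the estimate is 50000 nM in this assay, within a range of 20000 nM to 150000 nM. This estimate means an expected step of a 1.3-fold higher number from compound 2 to compound 4 (0.10 log units; within the scatter), with a fair chance that compound 4 instead returns only a limit.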

Compound 4, half-maximal cytotoxic concentration: > 100000 nM
Compound 4: no number, only a limit (the forecaster's own chance of this, stated with the estimate: 40%); middle value at least 2.0-fold (0.30 log units) away from the limit.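

Amino in place of tert-butyl on an aromatic carbon gives the first step that can be read in this assay, and it shows that this position, on a six-membered aromatic ring of carbon only, does not leave the read-out unchanged: an at least 2.5-fold higher number from compound 2 to compound 4 (0.39 log units; beyond the scatter). The entry for compound 4 is a limit of the assay and not a number, so this step has a lower bound and no known size. The read-out now ends at this limit for a second compound, which narrows what the upper end of the set can show: the limit of > 100000 nM in this assay, at which 2 of the 4 values shown sit.

The compounds shown leave open what single number compound 4 would give, and whether the step follows from the arrival of amino or from the departure of tert-butyl, since one exchange cannot separate the two. They also leave open how a hydroxyl, a methoxy group or a carboxylic acid on this same aromatic carbon would read in this assay, and whether a longer chain would alter the step from tert-butyl to amino.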